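The source may hold more compounds than are shown below. What is called first, only, known or untested is meant among the compounds shown, and "the series" means these compounds.

Measured compounds:
Compound 1, `CCCn1c(=O)n(CC(=O)O)c(=O)c2[nH]cnc21`: in an assay on Cerebral cortex for binding affinity to adenosine receptor A1 (Cavia porcellus), read by radioligand binding (a lower number here means a stronger inhibitor, a higher number a weaker inhibitor), compound 1 gives > 200000 nM.
Compound 2, `CCCn1c(=O)n(CCN(C)C)c(=O)c2[nH]cnc21`: in this assay compound 2 gives 4300 nM.

Compound 1 stands at the edge of what this assay reports: its value is a limit and not a number, as the limit of > 200000 nM in this assay, at which 1 of the 2 values shown sits, shows. Compound 3, `CCCn1c(=O)n(CCCN(C)C)c(=O)c2[nH]cnc21`, has not yet been measured in this assay. It differs from compound 1 in one place: 2-(dimethylamino)ethyl in place of carboxy on a saturated chain carbon bound to an aromatic nitrogen. Among the compounds with values here, the only measured step that bears on this change is an at least 46-fold lower number from compound 1 to compound 2 (1.66 log units; beyond the scatter), in which carboxy was exchanged for (dimethylamino)methyl on a saturated chain carbon bound to an aromatic nitrogen. Compound 3 carries the same kind of replacement, with the chain cut one bond further out, so a step of comparable size and in the same direction is expected. The expected step is an at least 50-fold lower number from compound 1 to compound 3 (1.69 log units; beyond the scatter). The estimate for compound 3 is 4000 nM, with a range from 1300 nM to 15000 nM. Only compound 2 supports this expectation, and whether the longer chain moves the number beyond the scatter cannot be read from these data.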

Compound 3, inhibition constant: 43200 nM
Compound 3: middle estimate off by 11-fold (1.03 log units), on the low side; the whole stated range lies below it.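

In this assay, within the data shown here, the length of the chain carrying the dimethylamino group matters at this position: one more chain carbon gives a 10-fold higher number from compound 2 to compound 3 (1.00 log units; beyond the scatter), which the earlier compounds could not show. Exchanging carboxy for 2-(dimethylamino)ethyl still gives an at least 4.6-fold lower number from compound 1 to compound 3 (0.66 log units; beyond the scatter), so the direction seen with compound 2 also holds for compound 3, although the longer chain gives up much of the advantage compound 2 has. The distance from compound 1 remains a bound rather than a measured gap because the value of compound 1 is a limit of the assay: the limit of > 200000 nM in this assay, at which 1 of the 3 values shown sits.

With only two chain lengths ending in dimethylamino, the compounds shown leave open whether a still longer chain would raise the number further, and whether a primary amine at the chain end would behave like the dimethylamino group. They also leave open how a carboxylic acid on a longer chain would read, and whether a plain propyl chain with no amine at its end would fall nearer to compound 2 or to compound 3.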